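Urea side chain variation on a triazolopyridine sulfonamide series

This account rests on a few compounds, and the source may have more. Where it says the series, first, only, none or still open, it means among the compounds named here.

Compound 1 `COc1ncc(-c2ccc3nc(NC(=O)N(C)C)nn3c2)cc1NS(=O)(=O)c1ccc(F)cc1` is the weaker of the two compounds measured in a functional assay on HCT-116 cells (Homo sapiens) for cytotoxicity, read by MTT assay, with a stated time of 72 h; on this read-out higher numbers stand for weaker inhibition and lower numbers for stronger inhibition: compound 1 gives 760 nM, whereas compound 2 `CCN(CC)CCNC(=O)Nc1nc2ccc(-c3cnc(OC)c(NS(=O)(=O)c4ccc(C)cc4)c3)cn2n1` gives 170 nM in this assay. Compound 3 `COc1ncc(-c2ccc3nc(NC(=O)NCCN4CCN(C)CC4)nn3c2)cc1NS(=O)(=O)c1ccc(F)cc1` differs from compound 1 by (2-(4-methylpiperazin-1-yl)ethyl)amino in place of dimethylamino on a carbonyl carbon. Among the measured compounds shown here, no directly comparable pair has been measured, but compound 2, which also carries a basic side chain on the urea, shows a lower number than compound 1, so a step beyond the scatter toward stronger inhibition is expected. The estimated step is a 3.0-fold lower number from compound 1 to compound 3 (0.48 log units; beyond the scatter). Compound 3 is thus expected to reach about 250 nM in this assay, plausibly between 100 nM and 700 nM.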

Compound 3, half-maximal inhibitory concentration: 260 nM
Compound 3: the middle estimate sits 1.0-fold (0.02 log units) below what was measured; the range from low to high includes it.
By their numbers in this assay, from the lowest: compounds 2 and 3 (each within the scatter of the next); then compound 1.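

On a carbonyl carbon of the shared core, (2-(4-methylpiperazin-1-yl)ethyl)amino in place of dimethylamino gives a 2.9-fold lower number from compound 1 to compound 3 (0.47 log units; beyond the scatter) in this assay. Among the compounds shown here, this is the first direct reading at this position: a larger group with a six-membered non-aromatic ring and a hydrogen-bond donor goes with a modest move toward stronger inhibition. No measured evidence accounts for the step. On these data alone, whether the ring or the chain matters remains open, as does whether a morpholine or a longer chain ending in a primary amine would give a similar number.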